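This account rests on a few compounds, and the source may have more. Where it says the series, first, only, none or still open, it means among the compounds named here.

Measured so far in a functional assay on A549 cells (Homo sapiens) for antiproliferative activity, read by MTT assay, with a stated time of 72 h; on this read-out higher numbers stand for weaker inhibition and lower numbers for stronger inhibition:
- compound 1 `C/C=C/C(=O)Nc1cccc(Oc2nc(Nc3ccn(C)n3)nc3c2CSCC3)c1` gives > 50000 nM (a limit of the assay)
- compound 2 `C/C=C/C(=O)Nc1cccc(Oc2nc(Nc3cccc(C#N)c3)nc3c2CSCC3)c1` gives 17200 nM

Going by the values given here, compound 2 holds the only actual number, the other entry being a limit. Compound 3 `CC(C)/C=C/C(=O)Nc1cccc(Oc2nc(Nc3cccc(C#N)c3)nc3c2CSCC3)c1` differs from compound 2 by isopropyl in place of methyl on a double-bonded chain carbon bound to a double-bonded chain carbon. Among the compounds with values here, the only measured step, an at least 2.9-fold lower number from compound 1 to compound 2 (0.46 log units; beyond the scatter), concerns the group on a nitrogen on an aromatic ring, so it gives no size for this change. No step beyond the scatter is therefore expected in this assay, and the estimated step is a 1.0-fold higher number from compound 2 to compound 3 (0.02 log units; within the scatter). Compound 3 is expected at about 18000 nM, within an estimated range of 7000 nM to 45000 nM.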

Compound 3, half-maximal inhibitory concentration: 35900 nM
Compound 3: middle estimate off by 2.0-fold (0.30 log units), on the low side, within the range that was stated.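

In this assay, isopropyl in place of methyl on a double-bonded chain carbon gives a 2.1-fold higher number from compound 2 to compound 3 (0.32 log units; beyond the scatter), so the read-out responds to this end of the chain, and the larger group goes with the weaker inhibition in this one pair. Going by these compounds alone, this is the first size for a change at this place, and it is separate from the group on the aromatic nitrogen. Any further loss would have little room to be read: the limit of > 50000 nM in this assay, at which 1 of the 3 values shown sits.

On these data alone, whether a dimethylamino group or a longer chain here would lower the number stays open. Also open, as far as these compounds go, is whether the step carries over to other groups on that nitrogen.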